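Methoxy to trifluoromethyl on the indole aryl, second pairing

The source may hold more compounds than are shown below. What is called first, only, known or untested is meant among the compounds shown, and "the series" means these compounds.

Measured so far in a functional assay on MCF7 cells (Homo sapiens) for antiproliferative activity, with a stated time of 5 days; on this read-out higher numbers stand for weaker inhibition and lower numbers for stronger inhibition:
compound 1 `CCCCc1ccc2[nH]c(-c3ccc(OC)cc3)c(/C=N/NC(=O)c3ccc(OC)cc3)c2c1` gives 226 nM
compound 2 `CCCCc1ccc2[nH]c(-c3ccc(C(F)(F)F)cc3)c(/C=N/NC(=O)c3ccc(OC)cc3)c2c1` gives 618 nM
compound 3 `CCCCc1ccc2[nH]c(-c3ccc(OC)cc3)c(/C=N/NC(=O)c3ccncc3)c2c1` gives 69 nM

Compound 4 `CCCCc1ccc2[nH]c(-c3ccc(C(F)(F)F)cc3)c(/C=N/NC(=O)c3ccncc3)c2c1` is not yet measured. It differs from compound 3 by trifluoromethyl in place of methoxy on an aromatic carbon. The same change, (trifluoromethyl in place of methoxy on an aromatic carbon), is already seen once, where it made a 2.7-fold higher number from compound 1 to compound 2 (0.44 log units; beyond the scatter). The two cores on which it sits differ by pyridin-4-yl in place of 4-methoxyphenyl on a carbonyl carbon, a change that on its own made a 3.3-fold lower number from compound 1 to compound 3 (0.52 log units; beyond the scatter). The place of the change is described in the same words for both pairs, so it counts as the same change on two cores.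

Among the compounds with values here, with only one earlier instance, the step from compound 3 to compound 4 is expected to resemble it, so a 2.8-fold higher number from compound 3 to compound 4 (0.44 log units; beyond the scatter) is estimated. On that basis compound 4 is expected to give about 190 nM in this assay, between 90 nM and 420 nM.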

Compound 4, half-maximal inhibitory concentration: 100 nM
The estimate for compound 4 lay 1.9-fold (0.28 log units) above the measured number, and the stated range covers the measured number.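

In this assay, trifluoromethyl in place of methoxy gives a 1.4-fold higher number from compound 3 to compound 4 (0.16 log units; within the scatter), within the scatter here although the earlier step lay beyond it, yet the two instances do not differ measurably: the same change on two cores in this assay, a 2.7-fold higher number (0.44 log units; beyond the scatter) from compound 1 to compound 2 and a 1.4-fold higher number (0.16 log units; within the scatter) from compound 3 to compound 4, 1.9-fold (0.28 log units) apart, within the scatter of two such steps

Pyridin-4-yl in place of 4-methoxyphenyl gives a 6.2-fold lower number from compound 2 to compound 4 (0.79 log units; beyond the scatter), and this too matches its earlier instance: the same change on two cores in this assay, a 3.3-fold lower number (0.52 log units; beyond the scatter) from compound 1 to compound 3 and a 6.2-fold lower number (0.79 log units; beyond the scatter) from compound 2 to compound 4, 1.9-fold (0.28 log units) apart, within the scatter of two such steps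

Each change therefore carries between the two cores shown within the scatter, but two instances per change fix no precise size and say nothing about other cores.

Open, as far as these compounds go, is how an amine or a nitrile in place of methoxy would behave on either core. Also open, from the compounds shown here alone, is whether these steps would hold if a longer chain replaced the butyl chain shared by all four compounds.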